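Putting a Chain Back in Place of Azido

This account rests on a few compounds, and the source may have more. Where it says the series, first, only, none or still open, it means among the compounds named here.

Compound 1 `CCCCC(=O)N(Cc1ccc(OC)c(O)c1)c1cc(OC)c(OC)c(OC)c1`: 170 nM
Compound 2 `COc1ccc(CN(C(=O)CN=[N+]=[N-])c2cc(OC)c(OC)c(OC)c2)cc1O`: 410 nM
Compound 3 `COc1ccc(CN(C(=O)CCCCCl)c2cc(OC)c(OC)c(OC)c2)cc1O`: not yet measured

In a functional assay on HCT-116 cells (Homo sapiens) for inhibition, read by MTT assay, with a stated time of 48 h (on this read-out higher numbers stand for weaker inhibition and lower numbers for stronger inhibition), compound 2 gives the higher of the two numbers, 410 nM. Compound 3 differs from it in one place: 3-chloropropyl in place of azido on a saturated chain carbon bound to a carbonyl carbon. Within the data shown here, only one measured step bears on this change, a 2.4-fold higher number from compound 1 to compound 2 (0.38 log units; beyond the scatter), where azido took the place of propyl at that same kind of carbon. Among the measured compounds shown here, compound 3 reverses that exchange in part, restoring a chain, but this chain carries chlorine, and no measured compound does. On that step alone, a modest move to a lower number is expected in this assay, close to the size of the measured step and possibly no larger than the scatter. The expected step is a 2.1-fold lower number from compound 2 to compound 3 (0.31 log units; beyond the scatter). The estimate for compound 3 is 200 nM, with a range from 90 nM to 450 nM.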

Compound 3, half-maximal inhibitory concentration: 220 nM
Compound 3: middle estimate off by 1.1-fold (0.04 log units), on the low side; measured number inside the range.
By their numbers in this assay, from the lowest: compounds 1, 3 and 2 (each within the scatter of the next, the first and the last beyond it).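

In this assay, 3-chloropropyl in place of azido on a saturated chain carbon bound to a carbonyl carbon gives a 1.9-fold lower number from compound 2 to compound 3 (0.27 log units; within the scatter), so this exchange cannot be told apart from repeat variation. Chloro in place of hydrogen on a saturated chain carbon, four bonds along the chain from a carbonyl carbon, gives a 1.3-fold higher number from compound 1 to compound 3 (0.11 log units; within the scatter), which is the first reading on a chlorine in this chain, and it leaves the number within the scatter of the unsubstituted chain. Compound 3 thus lies within the scatter of both compound 1 and compound 2, although those two lie beyond the scatter of each other.

From the compounds shown here alone, whether an amine or a carboxylic acid in place of chloro, or a longer chain, would shift the number beyond the scatter remains open. Nothing available explains why these compounds give the numbers they do.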